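This account rests on a few compounds, and the source may have more. Where it says the series, first, only, none or still open, it means among the compounds named here.

Compound 1 `CCC[C@H](O)Nc1nc(Nc2ccc(-c3ncccn3)cc2)c2ncn(C(C)C)c2n1`: 500 nM
Compound 2 `CCC[C@H](O)Nc1nc(Nc2ccc(-c3cncnc3)cc2)c2ncn(C(C)C)c2n1`: 70 nM
Compound 3 `CCC[C@@H](O)Nc1nc(Nc2cccc(-c3ncccn3)c2)c2ncn(C(C)C)c2n1`: 300 nM

Three compounds were measured in an assay on isolated protein (Asteroidea) for inhibition of G2/mitotic-specific cyclin-B (Asterina pectinifera), read by scintillation counting and 33P incorporation, with a stated time of 30 min; on this read-out lower numbers stand for stronger inhibition and higher numbers for weaker inhibition. Compound 1 gives 500 nM in this assay, compound 2 gives 70 nM and compound 3 gives 300 nM. Compounds 1 and 2 share a core and differ in one place, (pyrimidin-5-yl in place of pyrimidin-2-yl on an aromatic carbon), and this change brought a 7.1-fold lower number from compound 1 to compound 2 (0.85 log units; beyond the scatter). Compound 3 has a different core; the difference between the two cores is not broken down here. The values of compound 3 and compound 1 lie within the scatter of each other, while compound 2 is beyond the scatter from compound 3.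

Compound 4 `CCC[C@@H](O)Nc1nc(Nc2cccc(-c3cncnc3)c2)c2ncn(C(C)C)c2n1` has not yet been measured in this assay. It relates to compound 3 as compound 2 relates to compound 1: pyrimidin-5-yl in place of pyrimidin-2-yl on an aromatic carbon. The change is the same kind of change, not the same, since in compound 1 the group sits para to a large group and in compound 3 meta to a large group. The account expects a step of a 5.0-fold lower number from compound 3 to compound 4 (0.70 log units; beyond the scatter), resting on compound 1 and compound 2, where the same kind of change brought a 7.1-fold lower number from compound 1 to compound 2 (0.85 log units; beyond the scatter). Compound 4 is therefore estimated at 60 nM, between 20 nM and 200 nM.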

Compound 4, half-maximal inhibitory concentration: 130 nM
The estimate for compound 4 lay 2.2-fold (0.34 log units) below the measured number, and the stated range covers the measured number.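

In this assay, putting pyrimidin-5-yl in place of pyrimidin-2-yl again brought a lower number on the second core, a 2.3-fold lower number from compound 3 to compound 4 (0.36 log units; beyond the scatter), so the direction of the change carried over from one core to the other. The size of the step did not carry over, and the gap between the two steps is beyond the scatter: the same change on two cores in this assay, a 7.1-fold lower number (0.85 log units; beyond the scatter) from compound 1 to compound 2 and a 2.3-fold lower number (0.36 log units; beyond the scatter) from compound 3 to compound 4, 3.1-fold (0.49 log units) apart, beyond the scatter of two such steps. Going by these compounds alone, this shows that the size of the step depends on the core it is made on, but with only two cores it does not show which part of the difference between them matters, nor does it give a size to expect on a further core.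

The compounds shown leave open how this place on the aromatic ring responds to a group other than a pyrimidine, such as an amine or a carboxylic acid. They also leave open whether the same change would hold with a longer chain in place of the hydroxyl-bearing chain.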